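The source may hold more compounds than are shown below. What is called first, only, known or untested is meant among the compounds shown, and "the series" means these compounds.

Measured compounds:
- compound 1, `CCOC(=O)C1=C(C)NC(COC)=C(C(=O)OC)C1c1ccccc1[N+](=O)[O-]`: in a functional assay on HEK293 cells for antagonist activity at Voltage-dependent L-type calcium channel subunit alpha-1D (Rattus norvegicus), read by FLIPR (on this read-out lower numbers stand for stronger inhibition and higher numbers for weaker inhibition), compound 1 gives 790 nM
- compound 2, `CCOC(=O)C1=C(C)NC(C)=C(C(=O)OCCOC)C1c1cccc([N+](=O)[O-])c1`: in this assay compound 2 gives 82 nM
- compound 3, `COC(=O)C1=C(C)NC(C)=C(C(=O)OCC(C)[N+](=O)[O-])C1c1cccc([N+](=O)[O-])c1`: in this assay compound 3 gives 111 nM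

Compound 3 stands second highest of the three numbers. Its nearest neighbour is compound 2, whose number is lower but within the scatter, so no order between compound 2 and compound 3 can be claimed. Compound 1 stands furthest from compound 3, with a higher number that lies beyond the scatter; compound 1 also differs from the other two in the pattern of substituents on the shared core, so the pair is not a single-change comparison.

Compound 4, `COC(=O)C1=C(C)NC(C)=C(C(=O)OCc2ccc(OC)cc2)C1c1cccc([N+](=O)[O-])c1`, has not yet been measured. It differs from compound 3 in one place: 4-methoxyphenyl in place of 1-nitroethyl on a saturated chain carbon bound to an oxygen next to a carbonyl group. No step between measured compounds touches this ester position, so there is no shown precedent for its size or direction. The change keeps the shared core and the aryl group of compound 3 unchanged. The step from compound 3 to compound 4 in this assay is expected to be a 1.0-fold lower number from compound 3 to compound 4 (0.00 log units; within the scatter), that is, none beyond the scatter. For compound 4 in this assay the estimate is 110 nM, with a range from 35 nM to 350 nM.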

Compound 4, half-maximal inhibitory concentration: 79 nM
Compound 4: middle estimate off by 1.4-fold (0.14 log units), on the high side; measured number inside the range.
By their numbers in this assay, from the lowest: compounds 4, 2 and 3 (each within the scatter of the next); then compound 1.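

In this assay, 4-methoxyphenyl in place of 1-nitroethyl on a saturated chain carbon bound to an oxygen next to a carbonyl group gives a 1.4-fold lower number from compound 3 to compound 4 (0.15 log units; within the scatter). This first step at the position shows that a group with no ring can give way to a larger one with a six-membered aromatic ring, with no change that can be read on this read-out. No measurement accompanies the step that would explain this outcome.

Going by these compounds, whether a plain phenyl, a longer chain, an amine or a carboxylic acid in the same place would also stay within the scatter remains open. A single step also leaves open whether this exchange would give a similar result with a different aryl group on the shared core.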